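The source may hold more compounds than are shown below. What is called first, only, known or untested is meant among the compounds shown, and "the series" means these compounds.

Compound 3 `CC(=O)Oc1ccc(-c2ccc(F)cc2F)cc1C(=O)Nc1ccccc1C` stands second highest of the three measured compounds in a functional assay on the whole organism (Ear) for inhibition, with Mus musculus as the target, at a dose of 40 mg/kg by the oral route (a lower number here means less inhibition, a higher number more inhibition at the dose given (going by the name of the read-out)), giving 19.6%. Compound 2 `CC(=O)Oc1ccc(-c2ccc(F)cc2F)cc1C(=O)NCc1ccccc1` gives 34.1%, and compound 1 `CC(=O)Oc1ccc(-c2ccc(F)cc2F)cc1C(=O)NC1CCCCC1` gives 0%. Compound 4 `CC(=O)Oc1ccc(-c2ccc(F)cc2F)cc1C(=O)Nc1cccc(C)c1` differs from compound 3 by 3-methylphenyl in place of 2-methylphenyl on an amide-type nitrogen. Among the compounds with values here, none of the measured steps moves a methyl around a ring; the steps of a number 34.1 percentage points higher from compound 1 to compound 2 (beyond the scatter), a number 19.6 percentage points higher from compound 1 to compound 3 (beyond the scatter) and a number 14.5 percentage points lower from compound 2 to compound 3 (beyond the scatter) each swap one kind of nitrogen substituent for another. Lacking a closer precedent, a step of a number 2.4 percentage points higher from compound 3 to compound 4 (within the scatter) is expected, likely within the scatter, and compound 4 is estimated at 22% with a range of 5% to 40%.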

Compound 4, a percentage reported as inhibition, in the whole organism at one dose (the size of the read-out at that dose, not a potency): 12.8%
Beside the measured number, compound 4's estimate is 9.2 percentage points above it; low and high end bracket the measured number.
By their numbers in this assay, from the lowest: compound 1; then compounds 4 and 3 (each within the scatter of the next); then compound 2.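

In this assay, within the data shown here, 3-methylphenyl in place of 2-methylphenyl on the amide-type nitrogen gives a number 6.8 percentage points lower from compound 3 to compound 4 (within the scatter), the first step here that stays within the scatter, so the two methylphenyl groups cannot be told apart. Against the other nitrogen substituents, 3-methylphenyl stands like 2-methylphenyl, with a number 21.3 percentage points lower from compound 2 to compound 4 (beyond the scatter) and a number 12.8 percentage points higher from compound 1 to compound 4 (beyond the scatter). No evidence is available on why these numbers fall as they do. The compounds shown leave open how an unsubstituted phenyl or a longer phenylethyl chain on this nitrogen would compare.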